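Opening the ring on the side chain of compound 2

A few compounds are considered here, and "the series" means these few. Any claim that something is new, unique, unknown or untested is made for them only; others in the source may bear on it.

Among the compounds with values here, compound 2 `CC(C)=CC[C@@H](OC(=O)C1CCOC1)C1=CC(=O)c2c(O)ccc(O)c2C1=O` stands highest of the two numbers measured so far: in a functional assay on DU-145 cells (Homo sapiens) for cytotoxicity, read by MTT assay (on this read-out higher numbers stand for weaker inhibition and lower numbers for stronger inhibition), compound 2 gives 47500 nM, while compound 1 `CC(C)=CC[C@@H](OC[C@@H](C)O)C1=CC(=O)c2c(O)ccc(O)c2C1=O` gives 14300 nM. Within the data shown here, the single measured step, a 3.3-fold higher number from compound 1 to compound 2 (0.52 log units; beyond the scatter), concerns a different part of the molecule and bears only loosely on what follows. Compound 3 `CCC(O)(CC)CC(=O)O[C@H](CC=C(C)C)C1=CC(=O)c2c(O)ccc(O)c2C1=O` arises from compound 2 by 2-ethyl-2-hydroxybutyl in place of oxolan-3-yl on a carbonyl carbon. Among the measured compounds shown here, with no measured step on exactly this change, only a small move toward a lower number is expected, a 1.6-fold lower number from compound 2 to compound 3 (0.20 log units; within the scatter). Compound 3 is therefore estimated to give 30000 nM, within a range from 12000 nM to 75000 nM.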

Compound 3, half-maximal inhibitory concentration: 67000 nM
Compound 3: middle estimate off by 2.2-fold (0.35 log units), on the low side; measured number inside the range.
By their numbers in this assay, from the lowest: compound 1; then compounds 2 and 3 (each within the scatter of the next).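

Putting the open 2-ethyl-2-hydroxybutyl chain on the carbonyl carbon in place of the oxolan-3-yl ring leaves the number in this assay within the usual scatter (a 1.4-fold higher number from compound 2 to compound 3 (0.15 log units; within the scatter)), so this change shows no measurable effect here. Against compound 1, the (2-ethyl-2-hydroxybutyl)carbonyl group gives a step beyond the scatter (a 4.7-fold higher number from compound 1 to compound 3 (0.67 log units; beyond the scatter)), the same direction as the step to the (oxolan-3-yl)carbonyl group. No measurement shown explains these numbers. Still open, going by these compounds, is whether a chain bearing an amine or a carboxylic acid on this carbonyl carbon would bring the number down.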